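A few compounds are considered here, and "the series" means these few. Any claim that something is new, unique, unknown or untested is made for them only; others in the source may bear on it.

Measured so far:
Compound 1 `CN(Cc1ccc2nccn2c1)c1nnc(-c2ccc(-c3ccccc3Cl)nc2)o1`, in an ADME assay on cells (Hepatocyte, Rattus norvegicus) for metabolic stability (on this read-out lower numbers stand for slow clearance and higher numbers for fast clearance), gives 16 uL/min.
Compound 2 `CNC(=O)c1sc(N2CC3CC2(CNC(=O)c2c[nH]c4ncc(C(F)(F)F)cc24)C3)nc1C(F)(F)F`, in this assay, gives 78 uL/min.

Within the data shown here, only these two compounds carry numbers at this point, and they share no common core, so no single structural step joins them. Compound 2 stands at the higher of the two numbers; compound 1 sits at a markedly lower number, and the gap between the two is wider than the usual scatter of repeated measurements, so compound 2 is the faster-cleared of the pair.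

The next compound, compound 3 `CNC(=O)c1sc(N2CC3CC2(CNC(=O)c2c[nH]c4ncccc24)C3)nc1C(F)(F)F`, has not yet been measured in this assay. It is built from compound 2 by one change: hydrogen in place of trifluoromethyl on an aromatic carbon. Among the measured compounds shown here, nothing measured so far shows what this particular change does to clearance, since no pair of measured compounds differs in just this way. Without such a guide, the step is expected to be modest and most likely toward a lower number, so that an expected step of a 1.6-fold lower number from compound 2 to compound 3 (0.19 log units; within the scatter) would land near the edge of the scatter. Compound 3 is therefore expected to give about 50 uL/min, within a range from 20 uL/min to 120 uL/min.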

Compound 3, intrinsic clearance in a liver preparation (reported as CLH), per the amount of preparation that the assay uses: 33 uL/min
Compound 3: middle estimate off by 1.5-fold (0.18 log units), on the high side; measured number inside the range.
By their numbers in this assay, from the lowest: compound 1; then compound 3; then compound 2.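

In this assay, among these compounds, putting hydrogen on this aromatic carbon in place of trifluoromethyl gives a 2.4-fold lower number from compound 2 to compound 3 (0.37 log units; beyond the scatter) as the first step in this set that joins two measured compounds differing in one place. This shows that the carbon two atoms from the ring nitrogen is not a silent position: the group it carries can shift the clearance number by more than repeat measurements would, and here hydrogen goes with the lower number. The data offer no measurement that would say why the number falls with this change, so the step stands as an observation only.

On these data alone, one step with two end points cannot show whether the number follows a trend across groups at this carbon, so it remains open whether a methyl, a chlorine or a methoxy here would give a number close to that of compound 3, close to that of compound 2, or outside both. As far as these compounds go, it is also open whether the same swap at the other trifluoromethyl of compound 3 would move the number in the same direction, and whether this step would carry over to a different core such as that of compound 1.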